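The source may hold more compounds than are shown below. What is called first, only, known or untested is meant among the compounds shown, and "the series" means these compounds.

Values in a functional assay on blood (Homo sapiens), with a stated time of 60 min, in the presence of a further agent that is not named here; a lower number here means that less compound is needed, a higher number that more compound is needed for the effect:
- compound 1 `NC(=O)C1(S(=O)(=O)c2ccc(Oc3ccc(OC(F)(F)F)cc3)cc2)CCC2(CCNCC2)C1`: 3700 nM
- compound 2 `O=C(Nc1ccccn1)C1(S(=O)(=O)c2ccc(Oc3ccc(OC(F)(F)F)cc3)cc2)CCC2(CCNCC2)C1`: > 15000 nM (a limit)
- compound 3 `CN(C)S(=O)(=O)NC(=O)C1(S(=O)(=O)c2ccc(Oc3ccc(OC(F)(F)F)cc3)cc2)CCC2(CCNCC2)C1`: > 15000 nM (a limit)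

Compound 3 has no exact number, only the limit > 15000 nM. Compound 4 `Nc1ccc(-c2cccs2)cc1NC(=O)C1(S(=O)(=O)c2ccc(Oc3ccc(OC(F)(F)F)cc3)cc2)CCC2(CCNCC2)C1` carries 2-amino-5-(thiophen-2-yl)phenyl in place of dimethylsulfamoyl on the amide-type nitrogen: 2-amino-5-(thiophen-2-yl)phenyl in place of dimethylsulfamoyl on an amide-type nitrogen. Among the compounds with values here, two measured steps bear on this, each replacing the amide hydrogen, and both lie beyond the scatter: an at least 4.0-fold higher number from compound 1 to compound 2 (0.60 log units; beyond the scatter), and an at least 4.0-fold higher number from compound 1 to compound 3 (0.60 log units; beyond the scatter). Compound 4 keeps a substituent on that nitrogen, and like compound 2 it has an aromatic ring there, so it is expected to stay near the limit in this assay, with no clear step in either direction. The expected step is a number no higher from compound 3 to compound 4 (the limit leaves the size open). For compound 4 the estimate is 15000 nM, with an expected range of 5000 nM to 40000 nM.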

Compound 4, half-maximal effective concentration: 900 nM
Compound 4: the middle estimate sits 17-fold (1.22 log units) above what was measured, and the stated range ends above it.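

In this assay a group on the amide-type nitrogen need not raise the number: 2-amino-5-(thiophen-2-yl)phenyl in place of the amide hydrogen gives a 4.1-fold lower number from compound 1 to compound 4 (0.61 log units; beyond the scatter) while the two earlier replacements of that hydrogen gave higher numbers. The same group gives an at least 16-fold lower number from compound 3 to compound 4 (1.22 log units; beyond the scatter) and an at least 16-fold lower number from compound 2 to compound 4 (1.22 log units; beyond the scatter) so the kind of group on that nitrogen matters. Those two steps start from a limit, not a number: the limit of > 15000 nM in this assay, at which 2 of the 4 values shown sit. The step between compound 2 and compound 3 cannot be read. Whether the amino group or the thiophene accounts for the lower number stays open, as does the outcome for a plain phenyl or a longer chain ending in a carboxylic acid on that nitrogen.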